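Methoxy in Place of Hydrogen on Compound 2

A few compounds are considered here, and "the series" means these few. Any claim that something is new, unique, unknown or untested is made for them only; others in the source may bear on it.

Of the compounds shown here, three sharing one core have been tested in a functional assay on MCF7 cells (Homo sapiens) for cytotoxicity, read by MTT assay, with a stated time of 24 h; on this read-out higher numbers stand for weaker inhibition and lower numbers for stronger inhibition. Compound 1 `O=Cc1cc2ccccc2n(Cc2ccccc2)c1=O` carries a phenyl group on a saturated chain carbon bound to an aromatic nitrogen; in this assay compound 1 gives 31900 nM. Compound 2 `C#CCn1c(=O)c(C=O)cc2ccccc21` has ethynyl in that place instead. For compound 2 this assay reports only a limit, > 100000 nM. That comparison gives an at least 3.1-fold higher number from compound 1 to compound 2 (0.49 log units; beyond the scatter). Compound 3 `C#CCn1c(=O)c(C=O)cc2cc(F)ccc21` adds fluoro on an aromatic carbon of the core. For compound 3 this assay again reports only a limit, > 100000 nM. The step that the two limits leave unreadable from compound 2 to compound 3 cannot be sized because both ends sit at the limit of > 100000 nM in this assay, at which 2 of the 3 values shown sit.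

Compound 4 `C#CCn1c(=O)c(C=O)cc2cc(OC)ccc21` has not yet been measured. It differs from compound 2 by methoxy in place of hydrogen on an aromatic carbon. Among the compounds with values here, the only measured step touching this aromatic carbon is the one from compound 2 to compound 3, and it is unreadable; nothing measured here involves methoxy. Since compound 3, the nearest parallel, stayed at > 100000 nM, compound 4 is expected to remain weak. The expected step is a step that the limit leaves unreadable from compound 2 to compound 4, likely not readable beyond the scatter. Compound 4 is estimated at 150000 nM, with a range from 50000 nM to 500000 nM.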

Compound 4, half-maximal inhibitory concentration: > 100000 nM
Compound 4 ended at the assay's limit (the forecaster's own chance of this, stated with the estimate: 75%); the middle value does not contradict the limit.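

Compound 4 gives only a limit in this assay, so the steps to it from compound 2 and compound 3 cannot be read, because all three compounds sit at the same limit: the limit of > 100000 nM in this assay, at which 3 of the 4 values shown sit.

The compounds shown leave open whether fluoro or methoxy in place of hydrogen on this aromatic carbon changes the read-out at all.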